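The compounds below may be only part of what the source reports. "The series", "measured", "known", "first", "only" and "open" are said of these compounds alone.

Measured so far: compound 1 `N/C(=N\O)c1cn([C@@H]2O[C@H](CO)[C@@H](O)[C@H]2O)c2nnnc(N)c12` gives 1500 nM in a functional assay on KB cells (Homo sapiens) for inhibition; on this read-out lower numbers stand for stronger inhibition and higher numbers for weaker inhibition; compound 2 `CCOC(=O)c1cn([C@@H]2O[C@H](CO)[C@@H](O)[C@H]2O)c2nnnc(N)c12` gives 80000 nM in this assay.

Among the compounds with values here, compound 2 holds the higher of the two numbers, standing apart from its only neighbour by a 53-fold higher number from compound 1 to compound 2 (1.73 log units; beyond the scatter). Compound 3 `N#C/N=C(\N)c1cn([C@@H]2O[C@H](CO)[C@@H](O)[C@H]2O)c2nnnc(N)c12` differs from compound 2 in one place: a group of 5 heavy atoms (2 carbon, 3 nitrogen; no ring) in place of a group of 5 heavy atoms (3 carbon, 2 oxygen; no ring), on an aromatic carbon. Within the data shown here, the sole measured step that bears on this change is the one in which a nitrogen-bearing group gave way to the ethoxycarbonyl, and it was large. Because a 53-fold higher number from compound 1 to compound 2 (1.73 log units; beyond the scatter) ran toward higher numbers, compound 3, whose entering group is again nitrogen-bearing, is expected to give a 20-fold lower number from compound 2 to compound 3 (1.30 log units; beyond the scatter). Compound 3 is estimated at 4000 nM, between 800 nM and 20000 nM.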

Compound 3, half-maximal inhibitory concentration: 5000 nM
Compound 3: middle estimate off by 1.3-fold (0.10 log units), on the low side; the range from low to high includes it.
By their numbers in this assay, from the lowest: compound 1; then compound 3; then compound 2.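

In this assay, replacing the ethoxycarbonyl on this aromatic carbon with a second nitrogen-bearing group gives a 16-fold lower number from compound 2 to compound 3 (1.20 log units; beyond the scatter), so the large gap seen with compound 1 does not belong to a single group. Among the nitrogen-bearing groups the substituent on the double-bonded nitrogen still counts: cyano in place of hydroxy gives a 3.3-fold higher number from compound 1 to compound 3 (0.52 log units; beyond the scatter), a modest step but beyond the scatter. Going by these compounds, whether a primary amide or a carboxylic acid on this carbon would stand nearer compound 1 or compound 2 remains open. Nothing shown here accounts for these steps.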